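This account rests on a few compounds, and the source may have more. Where it says the series, first, only, none or still open, it means among the compounds named here.

Measured compounds:
- compound 1 `FC(F)(F)c1ccc(COc2nc3ccccc3s2)cc1`, which in a functional assay on the whole organism with Mus musculus as the target, with a stated time of 1 h, at a dose of 100 mg/kg by the intraperitoneal route (a lower number here means less inhibition, a higher number more inhibition at the dose given (going by the name of the read-out)), gives 12.2%
- compound 2 `Fc1ccc(COc2nc3ccccc3s2)cc1`, which in this assay gives 90.7%

Compound 2 stands highest of the two numbers in this assay; its nearest neighbour is compound 1, and the step of a number 78.5 percentage points higher from compound 1 to compound 2 (beyond the scatter) separates them. Compound 3 `Clc1ccc(COc2nc3ccccc3s2)cc1` has not yet been measured. It differs from compound 2 in one place: chloro in place of fluoro on an aromatic carbon. Going by the values given here, the only measured step, a number 78.5 percentage points higher from compound 1 to compound 2 (beyond the scatter), concerns a different exchange on the same aromatic carbon and bears on the present change only loosely: it shows that the group at this position can move the read-out in this assay by a large amount, but it does not show what chloro itself does. A moderate fall from compound 2 is therefore expected, with wide uncertainty. For compound 3 the estimate in this assay is 68%, within 30% to 95%, which means an expected step of a number 22.7 percentage points lower from compound 2 to compound 3 (beyond the scatter).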

Compound 3, a percentage reported as inhibition, in the whole organism at one dose (the size of the read-out at that dose, not a potency): 82.9%
The estimate for compound 3 lay 14.9 percentage points below the measured number, and the stated range covers the measured number.
By their numbers in this assay, from the lowest: compound 1; then compounds 3 and 2 (each within the scatter of the next).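

In this assay, the step for chloro in place of fluoro reads a number 7.8 percentage points lower from compound 2 to compound 3 (within the scatter), so at this position the two halogens cannot be told apart. Chloro in place of trifluoromethyl gives a number 70.7 percentage points higher from compound 1 to compound 3 (beyond the scatter), which shows that the large gap seen with fluoro recurs with a second single-atom group, so the low number of compound 1 now stands apart from two neighbours rather than one. No measurement at hand accounts for why trifluoromethyl differs from both.

The compounds shown leave open whether the high read-out extends to bromo or is matched by a methyl, a methoxy group, an amine or a carboxylic acid on this aromatic carbon. They also leave open what the unsubstituted ring would give, which would show whether either halogen contributes at all.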